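Series notes: cyanosulfanyl chain exchanged for a diamine

The source may hold more compounds than are shown below. What is called first, only, known or untested is meant among the compounds shown, and "the series" means these compounds.

Compound 1, `CCSCCc1c[nH]c2ccc(F)cc12`, in an assay on isolated protein (urine) for inhibition of Myeloperoxidase (Homo sapiens), with a stated time of 5 min; on this read-out higher numbers stand for weaker inhibition and lower numbers for stronger inhibition: a limit only, > 100 nM.
Compound 2, `N#CSCCCc1c[nH]c2ccc(F)cc12`, in this assay: 5 nM.

Among the compounds with values here, compound 2 holds the only real number in the set; the other value is a limit, as recorded in the limit of > 100 nM in this assay, at which 1 of the 2 values shown sits. Within the data shown here, the single measured step, an at least 20-fold lower number from compound 1 to compound 2 (1.30 log units; beyond the scatter), is large and runs toward stronger inhibition. Compound 3, `NCC(N)CCc1c[nH]c2ccc(F)cc12`, differs from compound 2 at the same place: 1,2-diaminoethyl in place of (cyanosulfanyl)methyl on a saturated chain carbon, two bonds along the chain from an aromatic carbon. The measured step bears on this change only loosely: it swaps ethylsulfanyl for cyanosulfanyl, whereas here the cyanosulfanyl group leaves and two amines enter. Compound 1, the chain without a cyanosulfanyl group, sat at the limit. Compound 3 is therefore expected to shift toward weaker inhibition, the estimated step being a 30-fold higher number from compound 2 to compound 3 (1.48 log units; beyond the scatter). Compound 3 is estimated at 150 nM, with a range from 20 nM to 1000 nM.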

Compound 3, half-maximal inhibitory concentration: 60 nM
Beside the measured number, compound 3's estimate is 2.5-fold (0.40 log units) above it, within the range that was stated.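

In this assay, the place on a saturated chain carbon, two bonds along the chain from an aromatic carbon, still gives a measured number without the cyanosulfanyl group: putting 1,2-diaminoethyl in place of (cyanosulfanyl)methyl gives a 12-fold higher number from compound 2 to compound 3 (1.08 log units; beyond the scatter). Set against ethylsulfanyl, the same diamine gives an at least 1.6-fold lower number from compound 1 to compound 3 (0.22 log units; that floor lies within the scatter), a floor within the scatter, so no order between these two compounds can be stated. Compound 1 is held only as a limit, not a number: the limit of > 100 nM in this assay, at which 1 of the 3 values shown sits.

The compounds shown do not separate the effect of losing the cyanosulfanyl group from that of adding the two amines. Going by these compounds, whether a single primary amine or a carboxylic acid at this place would read nearer compound 2 or compound 3 also stays open.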